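A Smaller Amide Partner on a Scaffold Without Readable Potency

A few compounds are considered here, and "the series" means these few. Any claim that something is new, unique, unknown or untested is made for them only; others in the source may bear on it.

Compound 3 `CCN(CC)S(=O)(=O)c1ccc(S(=O)(=O)N2CCC[C@@H](C(=O)N3CCC(C(F)(F)F)CC3)C2)cc1` is one of three compounds in a series sharing a core and varying only at two places. In a functional assay on MIA PaCa-2 cells (Homo sapiens) for inhibition, read by MTT assay, with a stated time of 3 days (on this read-out lower numbers stand for stronger inhibition and higher numbers for weaker inhibition), compound 3 gives > 10000 nM, which is a limit of the assay rather than a number. Its neighbours stand no better. In this assay compound 1 `CCN(CC)S(=O)(=O)c1ccc(S(=O)(=O)N2CCC[C@@H](C(=O)N3CCC(F)(F)CC3)C2)cc1` gives > 10000 nM, again a limit. Compound 2 `O=C([C@@H]1CCCN(S(=O)(=O)c2ccc(S(=O)(=O)C3CCC3)cc2)C1)N1CCC(F)(F)CC1` gives > 3000 nM in this assay, also a limit. The step that the two limits leave unreadable from compound 1 to compound 2 and the step that the two limits leave unreadable from compound 1 to compound 3 are therefore both unreadable in size, as the limit of > 10000 nM in this assay, at which 2 of the 3 values shown sit, and the limit of > 3000 nM in this assay, at which 1 of the 3 values shown sits, make plain.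

Compound 4 `CCN(CC)S(=O)(=O)c1ccc(S(=O)(=O)N2CCC[C@@H](C(=O)N[C@@H]3CCOC3)C2)cc1` differs from compound 3 by (oxolan-3-yl)amino in place of 4-(trifluoromethyl)piperidin-1-yl on a carbonyl carbon. Among the compounds with values here, none of the measured steps bears on this change, since every value so far is a limit, so no step of a known size can be carried over. Compound 4 is estimated at 12000 nM, between 3000 nM and 40000 nM, in this assay. The step that the limit leaves unreadable from compound 3 to compound 4 is expected to be none beyond the scatter, with a further limit the most likely outcome.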

Compound 4, half-maximal inhibitory concentration: > 10000 nM
Compound 4 gave a limit, no number (the forecaster's own chance of this, stated with the estimate: 80%); the middle value does not contradict the limit.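

In this assay compound 4 gives > 10000 nM, a limit and not a number. Its steps from compound 3 and from compound 1 therefore cannot be read: the limit of > 10000 nM in this assay, at which 3 of the 4 values shown sit.

The compounds shown leave open whether changing the group on the carbonyl carbon alters inhibition in this assay at all.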